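Acyloxyalkyl carbamates in the shared core: stability notes

The source may hold more compounds than are shown below. What is called first, only, known or untested is meant among the compounds shown, and "the series" means these compounds.

Compound 1 `CC(C)C(=O)OCOC(=O)N1CCN(C(=O)c2nc(Nc3cc(C4CC4)[nH]n3)c3cc(Cl)ccc3n2)C[C@H]1C` carries an (isopropylcarbonyl)oxy group on the saturated chain carbon bound to an oxygen next to the carbamate carbonyl. In an ADME assay on a cell-free system (plasma, Homo sapiens), read by HPLC, with a stated time of 120 min, at 37 degrees C (on this read-out lower numbers stand for a less stable compound and higher numbers for a more stable compound), compound 1 gives 6.1%, the lowest of the three numbers in hand. Compound 2 `CCCCCOC(=O)N1CCN(C(=O)c2nc(Nc3cc(C4CC4)[nH]n3)c3cc(Cl)ccc3n2)C[C@H]1C`, with butyl in that place, gives 74.4% in this assay, and compound 3 `COC(=O)N1CCN(C(=O)c2nc(Nc3cc(C4CC4)[nH]n3)c3cc(Cl)ccc3n2)C[C@H]1C`, with hydrogen there, gives 84.6%. The corresponding steps are a number 68.3 percentage points higher from compound 1 to compound 2 (beyond the scatter) and a number 78.5 percentage points higher from compound 1 to compound 3 (beyond the scatter); between the two replacements the step is a number 10.2 percentage points higher from compound 2 to compound 3 (beyond the scatter).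

Compound 4 `CC(OC(=O)C(C)C)OC(=O)N1CCN(C(=O)c2nc(Nc3cc(C4CC4)[nH]n3)c3cc(Cl)ccc3n2)C[C@H]1C` differs from compound 1 by methyl in place of hydrogen on a saturated chain carbon bound to two oxygens next to a carbonyl group. The (isopropylcarbonyl)oxy group stays in place. Among the compounds with values here, no measured step matches this change: the two large steps from compound 1 each remove the (isopropylcarbonyl)oxy group entirely, which compound 4 does not do. Within the data shown here, the only guide is that compound 1, the one compound that keeps this group, sits far below the others.

Compound 4 is therefore expected to stay near the low end, with a step of a number 8.9 percentage points higher from compound 1 to compound 4 (within the scatter) in this assay, small and possibly within the scatter. The estimate for compound 4 in this assay is 15%, with a range from 3% to 45%.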

Compound 4, percent of the compound remaining: 17.4%
The estimate for compound 4 lay 2.4 percentage points below the measured number; the range from low to high includes it.
By their numbers in this assay, from the lowest: compound 1; then compound 4; then compound 2; then compound 3.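

In this assay methyl in place of hydrogen on a saturated chain carbon bound to two oxygens next to a carbonyl group gives a number 11.3 percentage points higher from compound 1 to compound 4 (beyond the scatter) as a modest step, which shows that this position responds to substitution even though the (isopropylcarbonyl)oxy group stays in place. That response remains small beside the other two changes: 1-((isopropylcarbonyl)oxy)ethyl in place of methyl on an oxygen next to a carbonyl group gives a number 67.2 percentage points lower from compound 3 to compound 4 (beyond the scatter) as a large step, and the same group in place of pentyl gives a number 57 percentage points lower from compound 2 to compound 4 (beyond the scatter) as another large step, so compound 1 and compound 4, the two compounds carrying the acyloxy group, remain the lowest of the four with none going against this. Nothing at hand bears on the reason for these differences.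

Going by these compounds, it remains open whether an ethyl, an isopropyl or a cyclohexyl group on that same carbon would extend the modest step seen with methyl. Also open, on these data alone, is how a pivaloyl, benzoyl or amine-bearing acyl group in place of the isopropylcarbonyl part would read in this assay on the shared core.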